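Series notes: from compound 2 to the unsubstituted compound 4

A few compounds are considered here, and "the series" means these few. Any claim that something is new, unique, unknown or untested is made for them only; others in the source may bear on it.

Measured so far:
compound 1, `CCn1nnc(-c2sc(-c3cnccn3)nc2O)n1`: in an assay on HEK293 cells for inhibition of transient receptor potential cation channel subfamily M member 8 (Homo sapiens), read by FLIPR, with stated times of 5 min and 3 min (on this read-out higher numbers stand for weaker inhibition and lower numbers for stronger inhibition), compound 1 gives 1890 nM
compound 2, `CCOC(=O)c1sc(-c2cccc(Cl)c2)nc1O`: in this assay compound 2 gives 1300 nM
compound 3, `O=C(c1sc(-c2cccc(F)c2)nc1O)N1CCCCO1`: in this assay compound 3 gives 167 nM

Compound 2 holds the second highest of the three numbers. Compound 1 lies within the usual scatter of compound 2, so the two cannot be told apart. Among the compounds with values here, compound 3 gives a clearly lower number, beyond the scatter, but compound 3 differs from compound 2 in more than one place, so its value shows only that compound 3 is the stronger of that pair.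

Compound 4, `CCOC(=O)c1sc(-c2ccccc2)nc1O`, is not yet measured. It differs from compound 2 in one place: hydrogen in place of chloro on an aromatic carbon. Within the data shown here, no pair among the measured compounds isolates this change, so the expectation rests on compound 2 alone. Losing the chloro is expected to cost some inhibition; the expected step is a 2.3-fold higher number from compound 2 to compound 4 (0.36 log units; beyond the scatter), a weakening that may only just clear the scatter. Compound 4 is therefore expected at about 3000 nM, with a range of 1000 nM to 9000 nM.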

Compound 4, half-maximal inhibitory concentration: 32 nM
Compound 4: the middle estimate sits 94-fold (1.97 log units) above what was measured; the whole stated range lies above it.
By their numbers in this assay, from the lowest: compound 4; then compound 3; then compounds 2 and 1 (each within the scatter of the next).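

Hydrogen in place of chloro on an aromatic carbon, meta to a large group, gives a 41-fold lower number from compound 2 to compound 4 (1.61 log units; beyond the scatter) in this assay and is the first change in the series that can be read on its own. The loss of this single chlorine atom brings a large gain in inhibition, so within the ethyl ester compounds the chloro at this place works against inhibition rather than for it. Within the data shown here, this position therefore responds strongly to what it carries, a sensitivity that the earlier compounds, which differ in more than one place, could not reveal.

As far as these compounds go, whether a methyl, a methoxy or a nitrile at this carbon would also raise the number remains open. So does whether the same change would give a step of similar size on the amide of compound 3 or on the core of compound 1. No measurement available here accounts for the size of this step.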